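A Double-Bond Geometry Step Beside a Missing Measurement

This account rests on a few compounds, and the source may have more. Where it says the series, first, only, none or still open, it means among the compounds named here.

Compound 1 `CCCCC/C=C\C[C@]1(O)C=CC(=O)/C1=C/C=C\CCCC(=O)OC`: 6000 nM
Compound 3 `CCCCC/C=C\C[C@]1(O)C=CC(=O)/C1=C/C=C/CCCC(=O)OC`: 4100 nM
Compound 2 `CCCCC/C=C\C[C@@]1(O)C=C(Cl)C(=O)/C1=C\C=C\CCCC(=O)OC`: "not determined" (no result reported)

In a functional assay on HT-29 cells (Homo sapiens) for cytotoxicity, read by sulforhodamine B assay, with a stated time of 72 h (on this read-out lower numbers stand for stronger inhibition and higher numbers for weaker inhibition), compound 1 gives 6000 nM, and in this assay compound 3 gives 4100 nM. Among the measured compounds shown here, the step of a 1.5-fold lower number from compound 1 to compound 3 (0.17 log units; within the scatter) is the only measured comparison in this set, and it is a pure change of configuration, as the fact that compounds 1 and 3 differ only in the configuration as drawn records. Compound 2 stands without a number in this assay, so there is no anchor of its own for the step that follows.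

Compound 4 `CCCCC/C=C\C[C@@]1(O)C=C(Cl)C(=O)/C1=C/C=C/CCCC(=O)OC` is the counterpart of compound 2 in the same sense that compound 3 is the counterpart of compound 1: the two compounds have the same atoms and bonds and differ only in configuration as drawn: 1 of 4 stereo elements differ; a double bond is drawn Z in compound 2 and E in compound 4. The measured step that bears on this change is a 1.5-fold lower number from compound 1 to compound 3 (0.17 log units; within the scatter), which stayed within the scatter. The same kind of geometric change is therefore expected to move the number in this assay by at most a small amount, in no reliable direction, with the added uncertainty that compound 2 itself has no value to start from. Taken together, compound 4 is estimated in this assay at 3000 nM, with a plausible range from 400 nM to 20000 nM.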

Compound 4, half-maximal inhibitory concentration: 2700 nM
The estimate for compound 4 lay 1.1-fold (0.05 log units) above the measured number, within the range that was stated.
By their numbers in this assay, from the lowest: compounds 4, 3 and 1 (each within the scatter of the next, the first and the last beyond it).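

In this assay compound 4 gives 2700 nM, but compound 2 has no reported result, so the step from compound 2 to compound 4 cannot be read. The compounds shown leave open whether the Z to E change of the double bond, measured between compound 1 and compound 3, has a comparable size between compound 2 and compound 4.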